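A few compounds are considered here, and "the series" means these few. Any claim that something is new, unique, unknown or untested is made for them only; others in the source may bear on it.

Three compounds share one core. For the measured compounds named here, compound 1, `COc1cc(Nc2nc3ccccc3nc2S(=O)(=O)c2ccccc2)cc(OC)c1`, is the first of them; in a functional assay on KB cells (Homo sapiens) for cytotoxicity, read by MTT assay, with a stated time of 72 h (a lower number here means a stronger inhibitor, a higher number a weaker inhibitor), compound 1 gives "not determined" (no result reported). Compound 2, `O=S(=O)(c1ccccc1)c1nc2ccccc2nc1Nc1ccc(F)cc1`, carries a fluoro where compound 3, `O=S(=O)(c1ccccc1)c1nc2ccccc2nc1Nc1ccc(C(F)(F)F)cc1`, carries a trifluoromethyl on an aromatic carbon. In this assay compound 2 gives only a limit of the assay, > 50000 nM. In this assay compound 3 likewise gives only a limit of the assay, > 50000 nM. The step that the two limits leave unreadable from compound 2 to compound 3 therefore cannot be read, as the limit of > 50000 nM in this assay, at which 2 of the 3 values shown sit, records. Compound 3 thus stands at the edge of what this assay can report, and no compound of the set has a numeric potency shown.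

Compound 4, `Cc1ccc(S(=O)(=O)c2nc3ccccc3nc2Nc2ccc(C(F)(F)F)cc2)cc1`, differs from compound 3 by methyl in place of hydrogen on an aromatic carbon. Going by the values given here, no measured step bears on this change: the only step, a step that the two limits leave unreadable from compound 2 to compound 3, is unreadable, and the set holds no number against which a gain or loss could be judged. Nothing in the data points toward a measurable potency. Compound 4 is therefore expected to remain at the limit of this assay, with an estimated 50000 nM and a range from 20000 nM to 120000 nM. The expected step of a number no higher from compound 3 to compound 4 (the limit leaves the size open) is estimated to lie within the scatter.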

Compound 4, half-maximal inhibitory concentration: 10300 nM
For compound 4 the middle estimate is 4.9-fold (0.69 log units) above the measured one; measured number outside the range, below it.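

For the compounds shown here, exchanging phenylsulfonyl for (4-methylphenyl)sulfonyl, with the methyl para to a large group, produces the first readable step of the set in this assay: an at least 4.8-fold lower number from compound 3 to compound 4 (0.68 log units; beyond the scatter) in this series. This shows that a single added methyl at this position is enough to bring a compound off the limit of the assay and onto a measured number, which the fluoro to trifluoromethyl exchange between compound 2 and compound 3 could not show, as that step cannot be read. The full size of the new step stays open because compound 3 holds only a limit: the limit of > 50000 nM in this assay, at which 2 of the 4 values shown sit.

The compounds shown do not tell whether this gain belongs to methyl in particular, or whether a chlorine, a methoxy, an amine, a carboxylic acid or a longer chain such as ethyl at the same place would do the same or more. They also leave open whether the methyl would have a like effect with fluoro in place of trifluoromethyl, as in compound 2, or on the dimethoxy-substituted compound 1.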